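Swapping the Acetyl Group for Two Methyls

The source may hold more compounds than are shown below. What is called first, only, known or untested is meant among the compounds shown, and "the series" means these compounds.

The two compounds measured here share one core and differ only in the group attached to the amine nitrogen. Compound 1 `CC1(C)Oc2ccc(C#N)cc2[C@@H](/N=C(\NC#N)Nc2ccc(Cl)cc2)[C@@H]1O` carries a chloro on that aromatic ring, and in a functional assay (aorta) with Rattus norvegicus as the target (on this read-out higher numbers stand for weaker inhibition and lower numbers for stronger inhibition), compound 1 gives 1800 nM. Compound 2 `CC(=O)c1ccc(N/C(=N/[C@@H]2c3cc(C#N)ccc3OC(C)(C)[C@H]2O)NC#N)cc1` carries an acetyl instead, and in this assay compound 2 gives 21000 nM. Among the measured compounds shown here, that single swap produced a 12-fold higher number from compound 1 to compound 2 (1.07 log units; beyond the scatter), so compound 2 stands as the higher of the two numbers, with compound 1 as its only neighbour.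

Compound 3 `Cc1ccc(N/C(=N/[C@@H]2c3cc(C#N)ccc3OC(C)(C)[C@H]2O)NC#N)cc1C` has not yet been measured. It differs from compound 2 as follows: 3,4-dimethylphenyl in place of 4-acetylphenyl on an amine nitrogen. For the measured compounds named here, the only measured step that bears on this change is the one from chloro to acetyl, a large rise in the number, and compound 3 takes the acetyl away again, although it places a 3,4-dimethylphenyl there rather than restoring the chloro. A lower number than compound 2 is therefore expected in this assay, estimated as a step of a 5.3-fold lower number from compound 2 to compound 3 (0.72 log units; beyond the scatter). For compound 3 the expected value is 4000 nM, with a range from 1200 nM to 13000 nM.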

Compound 3, half-maximal inhibitory concentration: 5100 nM
Compound 3: the middle estimate sits 1.3-fold (0.11 log units) below what was measured; the measured number falls inside the stated range.
By their numbers in this assay, from the lowest: compound 1; then compound 3; then compound 2.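

In this assay the aromatic group on the amine nitrogen now has three measured forms, and every step between them is printed as beyond the scatter, so the number at this position changes with the group placed there. Replacing 4-acetylphenyl with 3,4-dimethylphenyl gives a 4.1-fold lower number from compound 2 to compound 3 (0.61 log units; beyond the scatter) and so takes back part of the rise seen with the acetyl, but this carbon-only group does not match the 4-chlorophenyl group, as the comparison with it shows a 2.8-fold higher number from compound 1 to compound 3 (0.45 log units; beyond the scatter) and leaves the chloro compound with the lowest number of the three. Nothing available here explains why the three groups fall in this order.

Because the new group carries two methyls at once, these compounds cannot show how much each methyl contributes to the result. Going by these compounds, it also remains open how a phenyl ring with a single methyl, a methoxy group or an amine would rank against these three, and whether any such group would bring the number below that of the chloro compound.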